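The compounds below may be only part of what the source reports. "The series", "measured", "known", "first", "only" and "open" are said of these compounds alone.

Three compounds have been measured in a functional assay on HCT-116 cells (Homo sapiens) for cytotoxicity, read by MTT assay, with a stated time of 2 days, tested at 10 uM; a lower number here means less inhibition, a higher number more inhibition at the concentration tested (going by the name of the read-out):

compound 1 `Cc1cccc(N2CCN(CCCNc3nc(NCc4ccco4)c4ccccc4n3)CC2)c1C`: 93.2%
compound 2 `Fc1ccc2nc(NCCCCN3CCN(c4cccc(Cl)c4Cl)CC3)nc(NCc3ccco3)c2c1`: 97.1%
compound 3 `Clc1cccc(N2CCN(CCCNc3nc(NCc4ccco4)c4ccccc4n3)CC2)c1Cl`: 94.5%

All three values lie within the usual scatter of one another. Compound 3 and compound 1 share a core and differ in one place, (2,3-dimethylphenyl in place of 2,3-dichlorophenyl on an amine nitrogen in a ring); this change gave the step of a number 1.3 percentage points lower from compound 3 to compound 1 (within the scatter). The difference between the core of compound 2 and the core of compound 3 is not broken down here.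

Compound 4 `Cc1cccc(N2CCN(CCCCNc3nc(NCc4ccco4)c4cc(F)ccc4n3)CC2)c1C` has not yet been measured. It is related to compound 2 by 2,3-dimethylphenyl in place of 2,3-dichlorophenyl on an amine nitrogen in a ring, the same change that leads from compound 3 to compound 1. Because the earlier step of a number 1.3 percentage points lower from compound 3 to compound 1 (within the scatter) stayed within the scatter, compound 4 is expected to show a step of a number 1.6 percentage points lower from compound 2 to compound 4 (within the scatter). The estimate for compound 4 is 95.5%, with a range from 88% to 99.5%.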

Compound 4, a percentage reported as inhibition, at one concentration (the size of the read-out at that concentration, not a potency): 97.4%
The estimate for compound 4 lay 1.9 percentage points below the measured number; low and high end bracket the measured number.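

In this assay, putting 2,3-dimethylphenyl in place of 2,3-dichlorophenyl gave a number 0.3 percentage points higher from compound 2 to compound 4 (within the scatter). Set beside the earlier step, the change behaves alike on both cores: the same change on two cores in this assay, a number 1.3 percentage points lower (within the scatter) from compound 3 to compound 1 and a number 0.3 percentage points higher (within the scatter) from compound 2 to compound 4, 1.6 percentage points apart, within the scatter of two such steps. Among the compounds shown here, this shows only that the swap leaves the read-out within the scatter on these two cores; since each step is that small, it shows no measurable effect of the change being carried over, and a single-concentration read-out gives no measure of potency.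

The compounds shown leave open what an unsubstituted phenyl, a methoxyphenyl or a pyridine would give on the same amine nitrogen. They also leave open whether the two groups would separate at lower concentrations or on a core with a longer chain.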